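Three Measured Compounds and One Unmeasured Change

The source may hold more compounds than are shown below. What is called first, only, known or untested is meant among the compounds shown, and "the series" means these compounds.

Compound 1 `Clc1ccc(C2=NN(c3ccc(-c4ccccc4)nn3)C(c3ccccc3)C2)cc1` gives 8750 nM in a functional assay on HepG2 cells (Homo sapiens) for antiproliferative activity, read by MTT assay, with a stated time of 24 h; on this read-out higher numbers stand for weaker inhibition and lower numbers for stronger inhibition. Compound 2 `Fc1ccc(C2CC(c3ccc(Cl)cc3)=NN2c2ccc(-c3ccccc3)nn2)cc1` gives 10000 nM in this assay. Compound 3 `FC(F)(F)c1ccc(C2CC(c3ccc(Cl)cc3)=NN2c2ccc(-c3ccccc3)nn2)cc1` gives 8330 nM in this assay.

Compound 3 has the lowest of the three numbers, but this means little on its own: the step of a 1.1-fold lower number from compound 1 to compound 3 (0.02 log units; within the scatter) and the step of a 1.2-fold lower number from compound 2 to compound 3 (0.08 log units; within the scatter) are both within the scatter, so the three compounds cannot be told apart in this assay.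

Compound 4 `COc1ccc(C2CC(c3ccc(Cl)cc3)=NN2c2ccc(-c3ccccc3)nn2)c(OC)c1` has not yet been measured. It differs from compound 3 in one place: 2,4-dimethoxyphenyl in place of 4-(trifluoromethyl)phenyl on a saturated ring carbon. The measured steps that bear on this change are the ones on the same aromatic ring, namely a 1.1-fold higher number from compound 1 to compound 2 (0.06 log units; within the scatter), a 1.1-fold lower number from compound 1 to compound 3 (0.02 log units; within the scatter) and a 1.2-fold lower number from compound 2 to compound 3 (0.08 log units; within the scatter). Each of them is within the scatter, so three different groups on this ring gave numbers that cannot be distinguished. The change to compound 4 is larger than any of those, adding two methoxy groups, but nothing measured suggests that this ring position shifts the number much. The expected step is therefore a 1.1-fold higher number from compound 3 to compound 4 (0.03 log units; within the scatter), that is, no step beyond the scatter. Compound 4 is estimated at 9000 nM, with a range from 4000 nM to 20000 nM.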

Compound 4, half-maximal inhibitory concentration: > 100000 nM
Compound 4: no number, only a limit (the forecaster's own chance of this, stated with the estimate: 20%); at least 11-fold (1.04 log units) between middle value and limit.
By their numbers in this assay, from the lowest: compounds 3, 1 and 2 (each within the scatter of the next). At a limit, above all of these: compound 4.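

For the compounds shown here, the measured position is less tolerant than the earlier compounds suggested: in this assay, phenyl, 4-fluorophenyl and 4-(trifluoromethyl)phenyl could not be told apart, yet 2,4-dimethoxyphenyl gives an at least 12-fold higher number from compound 3 to compound 4 (1.07 log units; beyond the scatter), an at least 10-fold higher number from compound 2 to compound 4 (1.00 log units; beyond the scatter) and an at least 11-fold higher number from compound 1 to compound 4 (1.05 log units; beyond the scatter), so inhibition is clearly weaker with this group. Heavy-atom count alone does not track this change, as the leaving 4-(trifluoromethyl)phenyl and the entering 2,4-dimethoxyphenyl have the same count and each holds one six-membered aromatic ring of carbon only, while they differ in the two hydrogen-bond acceptors that only the entering group carries. Compound 4 has a limit and not a number, so the full size of these steps stays unknown: the limit of > 100000 nM in this assay, at which 1 of the 4 values shown sits.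

The compounds shown cannot say whether both methoxy groups are needed for this loss, since no phenyl ring with a single methoxy group appears among them, and they cannot link the loss to the acceptors themselves. On these data alone, how an amine or a carboxylic acid on this ring would behave also remains open, as does the effect of a longer chain at this saturated ring carbon.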